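The compounds below may be only part of what the source reports. "The series", "measured", "known", "first", "only" and "open" are said of these compounds alone.

Measured compounds:
Compound 1 `COc1cc(Cc2nc3c(N)nc(F)nc3n2CCOC(C)C)cc(OC)c1OC` gives 15800 nM in a functional assay on MCF7 cells (Homo sapiens) for antiproliferative activity; a higher number here means a weaker inhibitor, a lower number a stronger inhibitor.
Compound 2 `COc1cc(Cc2nc3c(N)ncnc3n2CCOC(C)C)cc(OC)c1OC` gives 38900 nM in this assay.
Compound 3 `CCCCn1c(Cc2cc(OC)c(OC)c(OC)c2)nc2c(N)nc(F)nc21` gives 24000 nM in this assay.

Among these three numbers compound 2 gives the highest; its gap to compound 3 lies within the scatter, and only the step of a 2.5-fold higher number from compound 1 to compound 2 (0.39 log units; beyond the scatter) lies beyond it. Compound 4 `COc1cc(Cc2nc3c(N)ncnc3n2C)cc(OC)c1OC` differs from compound 2 in one place: hydrogen in place of isopropoxymethyl on a saturated chain carbon bound to an aromatic nitrogen. Going by the values given here, the only measured step that touches this chain is a 1.5-fold higher number from compound 1 to compound 3 (0.18 log units; within the scatter), a change to the same chain that stayed within the scatter; no measured step removes the chain outright. On that slender basis the step of a 1.2-fold higher number from compound 2 to compound 4 (0.06 log units; within the scatter) is expected to be small, if anything toward a higher number. Compound 4 is therefore estimated at 45000 nM, within 15000 nM to 130000 nM.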

Compound 4, half-maximal inhibitory concentration: 70800 nM
Beside the measured number, compound 4's estimate is 1.6-fold (0.20 log units) below it; low and high end bracket the measured number.
By their numbers in this assay, from the lowest: compounds 1, 3, 2 and 4 (each within the scatter of the next, the first and the last beyond it).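

In this assay, cutting 2-isopropoxyethyl back to methyl gives a 1.8-fold higher number from compound 2 to compound 4 (0.26 log units; within the scatter) and so stays within the scatter, even though isopropoxymethyl and its 5 heavy atoms leave outright. The earlier compounds had shown only ethyl taking the place of isopropoxy on this chain, whereas this step shows that the whole isopropoxymethyl group can go from this saturated chain carbon bound to an aromatic nitrogen with no change beyond the scatter. Still open, as far as these compounds go, is whether an amine or a carboxylic acid on this chain would move the number beyond the scatter. Also open, from the compounds shown here alone, is whether fluoro in place of hydrogen on the aromatic carbon would matter with methyl on the nitrogen. Nothing shown here gives a reason for this result.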